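The compounds below may be only part of what the source reports. "The series", "measured", "known", "first", "only" and "open" are said of these compounds alone.

Among the measured compounds shown here, in a physicochemical assay (a higher number here means a weaker inhibitor, a lower number a stronger inhibitor), compound 1 `Oc1ccc(-c2nnc(S)n2/N=C/c2ccccc2)cc1` gives 24 ug/mL and compound 2 `O=[N+]([O-])c1cccc(/C=N/n2c(S)nnc2-c2ccc(O)cc2)c1` gives 38 ug/mL as the only other number, so the two lie within the scatter of each other and neither stands apart. Compound 3 `Oc1ccc(-c2nnc(S)n2/N=C/c2ccccc2Cl)cc1` differs from compound 1 by chloro in place of hydrogen on an aromatic carbon in one place: chloro in place of hydrogen on an aromatic carbon, ortho to a large group. For the measured compounds named here, the one measured step that bears on this change is nitro in place of hydrogen on an aromatic carbon, a 1.6-fold higher number from compound 1 to compound 2 (0.20 log units; within the scatter) and only a weak guide, since it is a single step and no measured compound carries chloro. On that evidence, no step beyond the scatter is expected in this assay for compound 3. The estimated 1.0-fold higher number from compound 1 to compound 3 (0.02 log units; within the scatter) is accordingly small. For compound 3 the expected value is 25 ug/mL with an estimated range from 11 ug/mL to 55 ug/mL on this thin basis.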

Compound 3, half-maximal inhibitory concentration: 60 ug/mL
The estimate for compound 3 lay 2.4-fold (0.38 log units) below the measured number, and the stated range ends below it.
By their numbers in this assay, from the lowest: compounds 1, 2 and 3 (each within the scatter of the next, the first and the last beyond it).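

In this assay, among the compounds shown here, the change from phenyl to 2-chlorophenyl gives a 2.5-fold higher number from compound 1 to compound 3 (0.40 log units; beyond the scatter), the first step to clear the scatter, and it points toward a weaker inhibitor. The earlier step, a 1.6-fold higher number from compound 1 to compound 2 (0.20 log units; within the scatter), stayed within the scatter, so only now is there a sign that a substituent on this phenyl can shift the number, though this rests on a single modest step. No measurement shown accounts for the step.

For the compounds shown here, whether the step follows from chloro itself or from its place, ortho to a large group, remains open, as only one group has been seen in that place. A methyl, methoxy or amine in the same place, or chloro elsewhere on the phenyl, would separate the two readings.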